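Dichlorophenyl variant of compound 1 in the cytotoxicity series

The source may report more compounds than this note shows. Statements on the series, on what has been measured and on what is new or still open speak of the compounds shown alone.

Measured compounds:
compound 1 `COc1cccc(/C=C2\CCC/C(=C\c3ccccc3Cl)C2=O)c1OC` gives > 20000 nM in a functional assay on A549 cells (Homo sapiens) for cytotoxicity, read by MTT assay, with a stated time of 72 h (a lower number here means a stronger inhibitor, a higher number a weaker inhibitor), a limit of the assay.
compound 2 `COc1cccc(/C=C2\CCC/C(=C\c3ccc(Cl)cc3)C2=O)c1OC` gives > 20000 nM in this assay, a limit of the assay.
compound 3 `COc1ccccc1/C=C1\CCC/C(=C\c2cccc(OC)c2OC)C1=O` gives > 20000 nM in this assay, a limit of the assay.

Compound 1 stands only at a limit in this assay; no number is known for it. All three values shown sit at the same limit (the limit of > 20000 nM in this assay, at which 3 of the 3 values shown sit), so the steps a step that the two limits leave unreadable from compound 1 to compound 2, a step that the two limits leave unreadable from compound 1 to compound 3 and a step that the two limits leave unreadable from compound 2 to compound 3 cannot be read in size or direction. Changing the substituent on the double-bonded chain carbon bound to a double-bonded ring carbon, whether the chlorophenyl pattern or chloro against methoxy, has left every compound at the limit.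

Compound 4 `COc1cccc(/C=C2\CCC/C(=C\c3cc(Cl)cc(Cl)c3)C2=O)c1OC` differs from compound 1 by 3,5-dichlorophenyl in place of 2-chlorophenyl on a double-bonded chain carbon bound to a double-bonded ring carbon. For the measured compounds named here, no measured step bears readably on this change; the only evidence is that all variants so far remain at the limit (the limit of > 20000 nM in this assay, at which 3 of the 3 values shown sit). Compound 4 is therefore expected to sit at or beyond the same limit, with an estimated step that the limit leaves unreadable from compound 1 to compound 4 from compound 1. The estimate for compound 4 in this assay is 30000 nM, expected to lie between 8000 nM and 100000 nM.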

Compound 4, half-maximal inhibitory concentration: 12500 nM
The estimate for compound 4 lay 2.4-fold (0.38 log units) above the measured number, within the range that was stated.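

For the compounds shown here, at the double-bonded chain carbon bound to a double-bonded ring carbon, 3,5-dichlorophenyl gives compound 4 the only value in this assay that is a number rather than a limit: the limit of > 20000 nM in this assay, at which 3 of the 4 values shown sit. This place now has a readable direction, with an at least 1.6-fold lower number from compound 1 to compound 4 (0.20 log units; that floor lies within the scatter), an at least 1.6-fold lower number from compound 2 to compound 4 (0.20 log units; that floor lies within the scatter) and an at least 1.6-fold lower number from compound 3 to compound 4 (0.20 log units; that floor lies within the scatter). Each step is only a floor and lies within the scatter, so no gain beyond the scatter is established, and the steps among compound 1, compound 2 and compound 3 still cannot be read.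

It remains open whether the step from any of these compounds to compound 4 depends on the two chlorines together or on the pattern they form. How 3,5-dimethoxyphenyl or a phenyl carrying an amine would read at this place is also unknown.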